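Benzylic hydroxy removal in the bicyclic lactone series

This account rests on a few compounds, and the source may have more. Where it says the series, first, only, none or still open, it means among the compounds named here.

Measured compounds in a functional assay on K562 cells (Homo sapiens) for antiproliferative activity, read by MTT assay, with a stated time of 72 h; on this read-out lower numbers stand for stronger inhibition and higher numbers for weaker inhibition:
compound 1 `O=C1C[C@H]2O[C@H]([C@H](O)c3ccccc3)[C@H](O)[C@H]2O1`: 410 nM
compound 2 `O=C(/C=C/c1ccccc1)O[C@H](c1ccccc1)[C@H]1O[C@@H]2CC(=O)O[C@@H]2[C@H]1O`: 3560 nM
compound 3 `O=C1C[C@H]2O[C@H]([C@H](OC(=O)c3ccccc3)c3ccccc3)[C@H](O)[C@H]2O1`: 230 nM

Compound 1 stands second highest of the three numbers; its nearest neighbour is compound 3, and the step of a 1.8-fold lower number from compound 1 to compound 3 (0.25 log units; within the scatter) is within the scatter. Compound 2 gives the highest number, and the step of a 15-fold lower number from compound 2 to compound 3 (1.19 log units; beyond the scatter) is the only large one seen so far, concerning the acyl group on the ester rather than the free alcohol.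

Compound 4 `O=C1C[C@H]2O[C@H](Cc3ccccc3)[C@H](O)[C@H]2O1` is now to be measured. Relative to compound 1 the change is hydrogen in place of hydroxy on a saturated chain carbon bound to an aromatic carbon and a saturated ring carbon. Among the compounds with values here, no measured step touches that carbon directly. The closest analogy is the step from compound 1 to compound 3, which replaced the hydrogen on that oxygen and stayed within the scatter, suggesting the site is not sensitive. Compound 4 is therefore expected to give a number close to compound 1, a 1.3-fold higher number from compound 1 to compound 4 (0.13 log units; within the scatter), with no step beyond the scatter. The estimate for compound 4 is 550 nM, within 200 nM to 1500 nM.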

Compound 4, half-maximal inhibitory concentration: 510 nM
Compound 4: the middle estimate sits 1.1-fold (0.03 log units) above what was measured; measured number inside the range.
By their numbers in this assay, from the lowest: compounds 3, 1 and 4 (each within the scatter of the next, the first and the last beyond it); then compound 2.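

Removing the hydroxy from the saturated chain carbon bound to an aromatic carbon and a saturated ring carbon gives a 1.2-fold higher number from compound 1 to compound 4 (0.09 log units; within the scatter) in this assay and thus no step beyond the scatter. The earlier step at this site only placed a benzoyl on the oxygen, whereas this one shows that the oxygen itself can be lost, along with one hydrogen-bond donor and one hydrogen-bond acceptor, with no change beyond the scatter in this read-out. No supporting data bear on why this site behaves this way.

Going by these compounds, whether an amine, a carboxylic acid or a methoxy on this carbon would also stay within the scatter of compound 1 remains open. Also open, on these data alone, is whether a longer chain in place of the single saturated carbon would keep the number there.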